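Aryl swap on the ring nitrogen: compound 2 to compound 3

A few compounds are considered here, and "the series" means these few. Any claim that something is new, unique, unknown or untested is made for them only; others in the source may bear on it.

Compound 1 `CC1(C)CCc2cc(C(=O)/C=C/c3ccc(OCc4cn(-c5ccc(Br)cc5)nn4)cc3)c(O)cc2O1` in a functional assay on IMR-32 cells (Homo sapiens) for antiproliferative activity, read by MTT assay (on this read-out higher numbers stand for weaker inhibition and lower numbers for stronger inhibition), gives 69400 nM. Compound 2 `CC1(C)CCc2c(ccc(C(=O)/C=C/c3ccc(OCc4cn(-c5ccc(Cl)cc5)nn4)cc3)c2O)O1` is reported in this assay as "not active" (no number reported); no number stands for it, so nothing can be compared against compound 1 beyond the fact that both are weak. Compound 3 `COc1ccc(-n2cc(COc3ccc(/C=C/C(=O)c4ccc5c(c4O)CCC(C)(C)O5)cc3)nn2)c([N+](=O)[O-])c1` differs from compound 2 by 4-methoxy-2-nitrophenyl in place of 4-chlorophenyl on an aromatic nitrogen. For the measured compounds named here, with no measured step behind this change, the expectation in this assay is no shift beyond the scatter, in either direction, and a real chance that only a limit is again reported. Compound 3 is expected near 80000 nM, within 30000 nM to 200000 nM.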

Compound 3, half-maximal inhibitory concentration: 132000 nM
Estimate against measurement, compound 3: 1.7-fold (0.22 log units) below, and the stated range covers the measured number.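

For the compounds shown here, compound 2 carries no number in this assay, so no step to compound 3 can be read. As far as these compounds go, whether 4-methoxy-2-nitrophenyl in place of 4-chlorophenyl shifts this read-out stays open. No evidence bears on the result.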